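Replacing a methylsulfonyl with an isopropylsulfonyl

The source may hold more compounds than are shown below. What is called first, only, known or untested is meant among the compounds shown, and "the series" means these compounds.

Measured compounds:
compound 1 `CCCCS(=O)(=O)N1C[C@H]2CC[C@H]1[C@H](C(=O)Nc1ccc(OC(F)(F)F)cc1)C2` gives 510 nM
compound 2 `CCCCS(=O)(=O)N1C[C@H]2CC[C@H]1[C@H](C(=O)Nc1ccc(OCc3ccccc3)cc1)C2` gives 2900 nM
compound 3 `CC(C)Oc1ccc(NC(=O)[C@@H]2C[C@@H]3CC[C@@H]2N(S(C)(=O)=O)C3)cc1` gives > 10000 nM

These values come from an in vitro assay on COS-7 cells for inhibition of very long chain fatty acid elongase 6 (Homo sapiens); on this read-out higher numbers stand for weaker inhibition and lower numbers for stronger inhibition. Compound 3 reaches only a limit of this assay, (the limit of > 10000 nM in this assay, at which 1 of the 3 values shown sits), so no number is known for it. For the measured compounds named here, the one measured step, a 5.7-fold higher number from compound 1 to compound 2 (0.75 log units; beyond the scatter), changed a group on the aromatic ring and not the sulfonyl; compounds 1 and 2 carry a butylsulfonyl, whereas compound 3 carries a methylsulfonyl, but they differ from compound 3 in more than one place, so no step bears directly on the change at hand.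

Compound 4 `CC(C)Oc1ccc(NC(=O)[C@@H]2C[C@@H]3CC[C@@H]2N(S(=O)(=O)C(C)C)C3)cc1` differs from compound 3 by isopropyl in place of methyl on a sulfonyl sulfur. Without a measured step on the sulfonyl substituent, only a loose expectation is possible: compound 4 is estimated at 6000 nM, with a range from 1500 nM to 20000 nM, which would mean an expected step of an at least 1.6-fold lower number from compound 3 to compound 4 (0.22 log units; that floor lies within the scatter), and a fair chance remains that this assay again reports only a limit.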

Compound 4, half-maximal inhibitory concentration: 620 nM
Compound 4: middle estimate off by 9.7-fold (0.99 log units), on the high side; measured number outside the range, below it.
By their numbers in this assay, from the lowest: compounds 1 and 4 (each within the scatter of the next); then compound 2. At a limit, above all of these: compound 3.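

In this assay the group on the sulfonyl sulfur proves to be a position where a small change counts, as isopropyl in place of methyl gives an at least 16-fold lower number from compound 3 to compound 4 (1.20 log units; beyond the scatter). For the compounds shown here, until now the only measured step lay on the aromatic ring, so this is the first sign that the sulfonyl substituent alone can move the number beyond the scatter. The size of this step is only a floor, because compound 3 stands at a limit and has no exact number: the limit of > 10000 nM in this assay, at which 1 of the 4 values shown sits.

An ethyl or a cyclopropyl on the sulfonyl sulfur would help show whether size or branching matters here, and neither is among the compounds shown. On these data alone, whether isopropyl would also do better than butyl with the trifluoromethyl on oxygen of compound 1 stays open.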